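A few compounds are considered here, and "the series" means these few. Any claim that something is new, unique, unknown or untested is made for them only; others in the source may bear on it.

Compound 1, with the structure `c1ccc(Sc2c(-c3ccccc3)nc3ccc(-c4ccccc4)cn23)cc1`, was tested in a functional assay on MDA-MB-231 cells (Homo sapiens) for inhibition, read by MTT assay, with a stated time of 48 h (a higher number here means a weaker inhibitor, a lower number a stronger inhibitor), where compound 1 gives 76700 nM. Among the two numbers available, this is the highest, so compound 1 is the weaker of the pair. The nearest comparison is compound 2, with the structure `N#Cc1ccc(-c2nc3ccccn3c2Sc2ccccc2)cc1`, which in this assay gives 17800 nM; the gap between the two lies beyond the usual scatter, but the two compounds differ in more than one place, so no single change can be read from them.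

Compound 3, with the structure `Clc1ccc2nc(-c3ccccc3)c(Sc3ccccc3)n2c1`, has not yet been measured. It differs from compound 1 in one place: chloro in place of phenyl on an aromatic carbon. Going by the values given here, no measured pair shows the effect of exactly this change, so the expectation rests on the two numbers at hand alone. The step from compound 1 to compound 3 is expected to be small, a 1.9-fold lower number from compound 1 to compound 3 (0.28 log units; within the scatter), most likely toward a somewhat lower number, though a step within the scatter would not be surprising. In this assay compound 3 is therefore estimated at 40000 nM, with a likely range from 10000 nM to 150000 nM.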

Compound 3, half-maximal inhibitory concentration: 55800 nM
Beside the measured number, compound 3's estimate is 1.4-fold (0.14 log units) below it, and the stated range covers the measured number.
By their numbers in this assay, from the lowest: compound 2; then compounds 3 and 1 (each within the scatter of the next).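

Going by these compounds alone, this is the first measured pair that isolates a single change: in this assay, putting chloro in place of phenyl on an aromatic carbon of the six-membered aromatic ring with 1 nitrogen gives a 1.4-fold lower number from compound 1 to compound 3 (0.14 log units; within the scatter). At this position, then, a group of 6 heavy atoms containing a whole aromatic ring can be exchanged for a single chlorine atom without a shift that stands clear of the usual scatter of repeated measurements, so the phenyl ring is not required to keep the number where it is. No measurement here bears on why these two groups read alike.

Going by these compounds, whether the same holds for other groups on this carbon, such as a methoxy group, an amine or a carboxylic acid, remains open, as does whether any group here can move the number beyond the scatter. Compound 2 differs from the other two compounds in more than one place, so the separate contributions of its changes, including the nitrile, cannot be read from these compounds.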